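Swapping propanoyl for methyl on sulfur

This account rests on a few compounds, and the source may have more. Where it says the series, first, only, none or still open, it means among the compounds named here.

In a functional assay on HT-29 cells (Homo sapiens) for inhibition, read by MTT assay, with a stated time of 96 h (on this read-out higher numbers stand for weaker inhibition of growth and lower numbers for stronger inhibition of growth), compound 1 (`CCCC(=O)SCCCCCCNC(=O)c1cc(-c2ccncc2)n[nH]1`) gives 12400 nM. On these data alone, compound 2 (`CCC(=O)SCCCCCCNC(=O)c1cc(-c2ccncc2)n[nH]1`) gives > 50000 nM, which is a limit of the assay and not a number, so its exact standing is unknown. Among the measured compounds shown here, the one measured step, hydrogen in place of methyl on a saturated chain carbon, is an at least 4.0-fold higher number from compound 1 to compound 2 (0.60 log units; beyond the scatter).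

Compound 3 (`CSCCCCCCNC(=O)c1cc(-c2ccncc2)n[nH]1`) carries methyl in place of propanoyl on a sulfur. For the measured compounds named here, this is a larger change than the measured one, but that single step from an at least 4.0-fold higher number from compound 1 to compound 2 (0.60 log units; beyond the scatter) is the only guide, and it points towards weaker inhibition of growth. No gain is therefore expected in this assay, and the result may again be only a limit. The expected step is a step that the limit leaves unreadable from compound 2 to compound 3. For compound 3 the estimated value is 60000 nM, with a range of 25000 nM to 150000 nM.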

Compound 3, concentration for 50% growth inhibition: > 50000 nM
Compound 3 was reported as a limit; the forecaster's own chance of this, stated with the estimate: 80%; the middle value lies beyond the limit too.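

In this assay compound 3 gives > 50000 nM, which is a limit of the assay and not a number. Methyl in place of propylcarbonyl on the sulfur is an at least 4.0-fold higher number from compound 1 to compound 3 (0.60 log units; beyond the scatter), so losing the carbonyl along with the chain also leaves the compound short of compound 1, and among these three compounds only compound 1 gives a readable number. No order can be read between compound 2 and compound 3, because both stop at the same limit: the limit of > 50000 nM in this assay, at which 2 of the 3 values shown sit.

Methyl takes away the carbonyl and the chain in a single change, so these compounds cannot show which of the two matters. Also open, on these data alone, is how a longer chain on the carbonyl, such as pentanoyl, would compare with compound 1.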